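The source may hold more compounds than are shown below. What is called first, only, known or untested is meant among the compounds shown, and "the series" means these compounds.

Three compounds set the scene: compound 1 `COc1ccc2c(c1)-c1cnc(n1C)OCCCCCCCCO2` and compound 2 `C=CCCCCOc1ncc(-c2ccccc2OC)n1C` and compound 3 `C=CCCCCOc1ncc(-c2cc(C(C)C)ccc2OC)n1C` all carry a methoxy-bearing benzene ring on the shared core. In a functional assay on B16-F10 cells (Mus musculus) for inhibition, read by colorimetric assay and MTT assay, with a stated time of 72 h (on this read-out lower numbers stand for stronger inhibition and higher numbers for weaker inhibition), compound 1 has the entry "not determined" (no result reported) and no number. Compound 2 has the entry "not determined" (no result reported) as well. In this assay, within the data shown here, compound 3 stands at 7000 nM and this is the only number available, so it cannot be ranked against anything.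

Compound 4 `C=CCCCCOc1ncc(-c2cc(Cl)ccc2OC)n1C` has chloro in place of isopropyl on an aromatic carbon, para to a methoxy group: chloro in place of isopropyl on an aromatic carbon is the whole difference from compound 3.

Among the measured compounds shown here, no measured pair shows what such a swap does. For that reason, no step beyond the usual scatter is expected in this assay and neither direction can be favoured. The estimated change is a 1.1-fold higher number from compound 3 to compound 4 (0.06 log units; within the scatter) and it stays modest. Compound 4 is expected at about 8000 nM with an estimated range from 3000 nM to 22000 nM in this test.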

Compound 4, half-maximal inhibitory concentration: 29000 nM
Beside the measured number, compound 4's estimate is 3.6-fold (0.56 log units) below it; measured number outside the range, above it.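

Among these compounds, this pair gives the first measured step on the shared core, and it shows that the group at this place, para to a methoxy group, matters in this assay: chloro in place of isopropyl gives a 4.1-fold higher number from compound 3 to compound 4 (0.62 log units; beyond the scatter). A higher number stands for weaker inhibition, so of these two groups isopropyl is the better one at this position, although this rests on a single pair of compounds. Nothing available bears on why the number rises with this swap.

As far as these compounds go, whether a tert-butyl group, a trifluoromethyl group or an amine at this place would give a lower number than isopropyl stays open. From the compounds shown here alone, it is also open whether the same swap would have a similar effect on the core of compound 1.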